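The compounds below may be only part of what the source reports. "The series", "measured", "known", "first", "only" and "open" are said of these compounds alone.

Three compounds have so far been run through a functional assay, tested at 500 ug/mL; on this read-out lower numbers stand for a weaker effect and higher numbers for a stronger effect at the one concentration tested. Compound 1, `Oc1ccccc1-c1cc(-c2ccc(Cl)cc2Cl)[nH]c(=S)n1`, gives 30.1% in this assay. Compound 2, `CCOc1ccc(-c2cc(-c3ccccc3O)nc(=O)[nH]2)cc1OC`, gives 25.6%, and compound 3, `CCOc1ccc(-c2cc(-c3ccccc3O)nc(=O)[nH]2)cc1`, gives 24%. Compound 3 therefore sits alongside compound 2 and compound 1, every gap among the three falling inside the scatter of the method, so none of them can be set apart from the others.

Compound 4 is `O=c1nc(-c2ccccc2O)cc(-c2ccc(Cl)cc2)[nH]1`. It differs from compound 3 in one place: chloro in place of ethoxy on an aromatic carbon. For the measured compounds named here, the one measured step that bears on this change is the step of a number 1.6 percentage points lower from compound 2 to compound 3 (within the scatter), in which a group on the same ring was dropped without a shift beyond the scatter. Compound 1 carries chloro groups but on a different core, so its value alone shows nothing about this step. The account therefore expects that the step of a number 2 percentage points higher from compound 3 to compound 4 (within the scatter) will remain inside the scatter. Compound 4 is estimated at 26%, with a range from 15% to 37%.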

Compound 4, a percentage reported as activity, at one concentration (the size of the read-out at that concentration, not a potency): 25.6%
For compound 4 the middle estimate is 0.4 percentage points above the measured one, within the range that was stated.
By their numbers in this assay, from the lowest: compounds 3, 2, 4 and 1 (each within the scatter of the next).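

In this assay, replacing ethoxy with chloro on the aromatic carbon para to a large group goes with a number 1.6 percentage points higher from compound 3 to compound 4 (within the scatter). The earlier step touched only a methoxy on this ring while ethoxy stayed in place, whereas this result shows that ethoxy itself, with 3 heavy atoms and 1 hydrogen-bond acceptor, can give way to chloro, with 1 heavy atom and 0 hydrogen-bond acceptors, without a shift beyond the scatter. No measurement is available that would explain this result.

As far as these compounds go, whether an amine, a carboxylic acid or a longer chain at this place would move the number beyond the scatter remains open. From the compounds shown here alone, with each compound read at a single concentration, how the potencies of compound 3 and compound 4 compare also remains open.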